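The source may report more compounds than this note shows. Statements on the series, on what has been measured and on what is new or still open speak of the compounds shown alone.

Measured compounds:
Compound 1, `N#C[C@]1(O)[C@H](O)[C@@H](CO)O[C@@H](n2cc(F)c(O)nc2=O)[C@@H]1O`, gives 32000 nM in a functional assay on CCRF-CEM cells (Homo sapiens); on this read-out lower numbers stand for stronger inhibition and higher numbers for weaker inhibition.
Compound 2, `N#C[C@]1(O)[C@H](O)[C@@H](CO)O[C@@H](n2ccc(O)nc2=O)[C@@H]1O`, gives > 500000 nM in this assay, which is a limit of the assay and not a number.

Compound 2 therefore stands only at a limit in this assay, and no number is known for it. Going by the values given here, the single measured step, an at least 15-fold higher number from compound 1 to compound 2 (1.19 log units; beyond the scatter), took away the fluoro from the aromatic carbon and ended at that limit (the limit of > 500000 nM in this assay, at which 1 of the 2 values shown sits). Compound 3, `Cc1cn([C@@H]2O[C@H](CO)[C@@H](O)[C@@](O)(C#N)[C@H]2O)c(=O)nc1O`, follows on from compound 2 by the change (methyl in place of hydrogen on an aromatic carbon). Among the compounds with values here, no measured step shows a methyl at this carbon, and the one step that touches the same carbon went to weaker inhibition when a substituent there was removed. Putting a methyl onto it is expected to leave compound 3 weak, with a real chance of the same limit, so the estimated step of an at least 1.6-fold lower number from compound 2 to compound 3 (0.22 log units; that floor lies within the scatter) is uncertain. Compound 3 is expected at 300000 nM, between 60000 nM and 1500000 nM.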

Compound 3, half-maximal inhibitory concentration: > 500000 nM
Compound 3 ended at the assay's limit (the forecaster's own chance of this, stated with the estimate: 50%); middle value at least 1.6-fold (0.22 log units) from the limit.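

In this assay, replacing the fluoro with a methyl gives an at least 15-fold higher number from compound 1 to compound 3 (1.19 log units; beyond the scatter), so a methyl on this aromatic carbon does not keep the level of inhibition seen with the fluoro. Compound 3 gives > 500000 nM, which is a limit of the assay and not a number. The step between compound 2 and compound 3 cannot be read, so hydrogen and methyl cannot be ordered, and of the three groups shown at this carbon, only the fluoro gives a measured number: the limit of > 500000 nM in this assay, at which 2 of the 3 values shown sit.

On these data alone, it remains open whether a chloro or an amine at this carbon would also give a measured number. Also open, as far as these compounds go, is whether compound 1 would keep its inhibition if a carboxylic acid took the place of the nitrile on the shared core.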